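Swapping one fluoro for hydrogen on compound 1

The source may report more compounds than this note shows. Statements on the series, on what has been measured and on what is new or still open speak of the compounds shown alone.

In a functional assay on A549 cells (Homo sapiens) for inhibition, read by MTT assay, with a stated time of 72 h (a higher number here means a weaker inhibitor, a lower number a stronger inhibitor), compound 1 `C=CC(=O)Nc1cc(Nc2nc3c(c(-c4cn(C)c5ccc(F)cc45)n2)CSCC3)c(OC)cc1N(C)CCN(C)C` gives 4550 nM and sits among three measured relatives. Compound 2 `C/C=C\C(=O)Nc1cc(Nc2nc3c(c(-c4cn(C)c5ccc(F)cc45)n2)CSCC3)c(OC)cc1N(C)CCN(C)C` gives 5310 nM and compound 3 `COc1cc(N(C)CCN(C)C)c(NC(=O)/C=C\C(C)C)cc1Nc1nc2c(c(-c3cn(C)c4ccc(F)cc34)n1)CSCC2` gives 1150 nM in the same test. Those numbers amount to a 1.2-fold higher number from compound 1 to compound 2 (0.07 log units; within the scatter) and to a 4.0-fold lower number from compound 1 to compound 3 (0.60 log units; beyond the scatter), so compound 1 stands level with compound 2, and only compound 3 lies clearly lower.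

Compound 4 `C=CC(=O)Nc1cc(Nc2nc3c(c(-c4cn(C)c5ccccc45)n2)CSCC3)c(OC)cc1N(C)CCN(C)C` differs from compound 1 in one place, described by hydrogen in place of fluoro on an aromatic carbon as the count of what changes. In words, this is hydrogen in place of fluoro on an aromatic carbon, which turns 5-fluoro-1-methyl-1H-indol-3-yl into 1-methyl-1H-indol-3-yl.

For the measured compounds named here, no measured step touches this fluoro. All of them alter the group on the carbonyl carbon, so they bear on the question only indirectly, by showing how far one small change has moved the number in this series. Going by the values given here, nothing here favours a direction, so no change beyond the scatter is expected, though a modest move like the one to compound 3 remains possible. The expected outcome is a 1.1-fold higher number from compound 1 to compound 4 (0.02 log units; within the scatter) as the central estimate. Compound 4 is estimated at 4800 nM in this assay, with an expected range from 2100 nM to 11000 nM as the likely span.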

Compound 4, half-maximal inhibitory concentration: 506 nM
Compound 4: middle estimate off by 9.5-fold (0.98 log units), on the high side; measured number below the stated range.
By their numbers in this assay, from the lowest: compound 4; then compound 3; then compounds 1 and 2 (each within the scatter of the next).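

In this assay, for the compounds shown here, replacing the single fluoro with hydrogen gives a 9.0-fold lower number from compound 1 to compound 4 (0.95 log units; beyond the scatter) on a carbon of the 5-fluoro-1-methyl-1H-indol-3-yl group, a part of the molecule that none of the earlier steps changed. Going by these compounds alone, the earlier steps, such as a 4.0-fold lower number from compound 1 to compound 3 (0.60 log units; beyond the scatter) and a 4.6-fold lower number from compound 2 to compound 3 (0.66 log units; beyond the scatter), showed only that the group on the carbonyl carbon can shift the number, whereas this pair shows that the ring at the other end of the molecule matters as well, even when the change removes just one heavy atom. Nothing measured here accounts for the size of this step.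

Within the data shown here, this swap is seen only with vinyl on the carbonyl carbon, so it remains unknown whether hydrogen would also give a lower number than fluoro alongside the prop-1-en-1-yl of compound 2 or the 3-methylbut-1-en-1-yl of compound 3. On these data alone, it is also open whether a chloro, a methyl or a methoxy on this same aromatic carbon would give a number closer to that of the fluoro compound or the hydrogen compound.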